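The compounds below may be only part of what the source reports. "The series", "measured", "known", "first", "only" and "open" are said of these compounds alone.

Compound 1, `O=C(Nc1ccccc1)c1cc(Br)ccc1O`, and compound 2, `O=C(Nc1ccccc1)c1cc(Br)cc(Br)c1O`, share one core; the counted difference between them is bromo in place of hydrogen on an aromatic carbon. In an ADME assay on HEK293 cells (Homo sapiens) for cytotoxicity, read by reporter gene assay and resazurin assay, with a stated time of 48 h (a higher number here means that more compound is tolerated, a lower number that less compound is tolerated), compound 1 gives 35000 nM, and in this assay compound 2 gives 34000 nM. The step that this change made is a 1.0-fold lower number from compound 1 to compound 2 (0.01 log units; within the scatter). Compound 3, `O=C(Nc1ccc(Sc2nc3ccccc3s2)cc1)c1ccccc1O`, is built on another core; how its core differs from that of compound 1 is not broken down here. In this assay compound 3 gives 74000 nM, the highest of the three numbers, and its gaps to compound 1 and to compound 2 both lie beyond the scatter.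

Compound 4, `O=C(Nc1ccc(Sc2nc3ccccc3s2)cc1)c1cccc(Br)c1O`, has not yet been measured. It differs from compound 3 by bromo in place of hydrogen on an aromatic carbon. Among the measured compounds shown here, this is the same kind of change as the one from compound 1 to compound 2, though the surroundings are not identical: in compound 1 the position is meta to a bromo group (1 heavy atom) and meta to a group of 9 heavy atoms, while in compound 3 it is meta to a large group. Because the earlier step was a 1.0-fold lower number from compound 1 to compound 2 (0.01 log units; within the scatter), the expected step in this assay is a 1.1-fold lower number from compound 3 to compound 4 (0.02 log units; within the scatter), again within the scatter. Compound 4 is therefore estimated to give 70000 nM in this assay, with a likely range from 35000 nM to 140000 nM.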

Compound 4, half-maximal cytotoxic concentration: 71000 nM
Compound 4: the middle estimate sits 1.0-fold (0.01 log units) below what was measured; low and high end bracket the measured number.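

In this assay, the new step is a 1.0-fold lower number from compound 3 to compound 4 (0.02 log units; within the scatter). Set beside the earlier step, the same swap of hydrogen for bromo carries over from the core of compound 1 to the core of compound 3 with no difference that stands out from the scatter: the same change on two cores in this assay, a 1.0-fold lower number (0.01 log units; within the scatter) from compound 1 to compound 2 and a 1.0-fold lower number (0.02 log units; within the scatter) from compound 3 to compound 4, 1.0-fold (0.01 log units) apart, within the scatter of two such steps This agreement is a modest finding, since it rests on only two pairs of compounds, neither step lies beyond the scatter, and so the series has not yet shown how a step of clear size would carry from one core to the other; nor does it show that a bromo would behave the same way on a third core or in any other assay.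

The compounds shown carry only hydrogen or bromo at the places compared, so it remains open whether a chloro group, a methoxy group or an amine on the same ring would also leave the number within the scatter. They also leave open what a carboxylic acid in place of the hydroxy group would do, and whether a longer chain in place of the bromo would give a step of any clear size.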